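The source may hold more compounds than are shown below. What is called first, only, known or untested is meant among the compounds shown, and "the series" means these compounds.

Compound 1 `CC(C)(C)c1ccc(C(=O)NCc2ccc(C(N)=O)cc2)cc1`: 3800 nM
Compound 2 `CN(C)C(=O)c1ccc(CNC(=O)c2ccc(C(C)(C)C)cc2)cc1`: 170 nM
Compound 3 `CC(C)(C)c1ccc(C(=O)NCc2ccc(SC(F)(F)F)cc2)cc1`: 0.4 nM

In an assay on HeLa cells with Bile acid receptor (Homo sapiens) as the target, read by a luciferase reporter, with a stated time of 24 h (on this read-out lower numbers stand for an effect already at smaller amounts and higher numbers for an effect only at larger amounts of compound), compound 3 stands lowest of the three numbers. The steps of a 430-fold lower number from compound 2 to compound 3 (2.63 log units; beyond the scatter) and a 9500-fold lower number from compound 1 to compound 3 (3.98 log units; beyond the scatter) show that both other compounds lie far above it. Compound 4 `CC(C)(C)c1ccc(C(=O)NCc2ccc(CCC(=O)O)cc2)cc1` differs from compound 3 by 2-carboxyethyl in place of (trifluoromethyl)sulfanyl on an aromatic carbon. For the measured compounds named here, no measured step involves a 2-carboxyethyl group. Going by the values given here, the steps that bear on the change run the other way: a 9500-fold lower number from compound 1 to compound 3 (3.98 log units; beyond the scatter) and a 430-fold lower number from compound 2 to compound 3 (2.63 log units; beyond the scatter), each large, and in each a group carrying a hydrogen-bond acceptor gave way to (trifluoromethyl)sulfanyl. Compound 4 moves back toward a group with a donor and an acceptor, so a large rise in number is expected, a 3800-fold higher number from compound 3 to compound 4 (3.57 log units; beyond the scatter). Compound 4 is estimated at 1500 nM in this assay, between 150 nM and 15000 nM.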

Compound 4, half-maximal effective concentration: 350 nM
Beside the measured number, compound 4's estimate is 4.3-fold (0.63 log units) above it; low and high end bracket the measured number.
By their numbers in this assay, from the lowest: compound 3; then compound 2; then compound 4; then compound 1.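

In this assay, 2-carboxyethyl at this position stays far from (trifluoromethyl)sulfanyl, with an 880-fold higher number from compound 3 to compound 4 (2.94 log units; beyond the scatter) as the cost of the change. The same group still improves on carbamoyl, with an 11-fold lower number from compound 1 to compound 4 (1.04 log units; beyond the scatter) as the gain, and sits modestly, though beyond the scatter, on the far side of dimethylcarbamoyl, with a 2.1-fold higher number from compound 2 to compound 4 (0.31 log units; beyond the scatter) as the gap. Nothing measured here explains this order.

The compounds shown leave open whether a carboxylic acid on a shorter or longer chain, its methyl ester or an amine would change this picture. They also leave open whether trifluoromethyl or trifluoromethoxy would match (trifluoromethyl)sulfanyl.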